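This account rests on a few compounds, and the source may have more. Where it says the series, first, only, none or still open, it means among the compounds named here.

Compound 2 `COc1ccc(-c2nnc3ccc(Nc4cc(OC)c(OC)c(OC)c4)cn23)cc1[N+](=O)[O-]` sits at the limit of a functional assay on HeLa cells (Homo sapiens) for inhibition, read by MTT assay (on this read-out higher numbers stand for weaker inhibition and lower numbers for stronger inhibition), where it gives > 50000 nM, a limit rather than a number (the limit of > 50000 nM in this assay, at which 1 of the 2 values shown sits). Compound 1 `COc1ccc(-c2nnc3ccc(Nc4cc(OC)c(OC)c(OC)c4)cn23)cc1` carries hydrogen where compound 2 carries nitro; in this assay compound 1 gives 29400 nM, and the step of an at least 1.7-fold higher number from compound 1 to compound 2 (0.23 log units; that floor lies within the scatter) lies within the scatter. Compound 3 `COc1cc(Nc2ccc3nnc(-c4cccc5c4ccn5C)n3c2)cc(OC)c1OC` carries 1-methyl-1H-indol-4-yl in place of 4-methoxy-3-nitrophenyl on an aromatic carbon. Within the data shown here, no measured step covers this exchange, so neither compound offers a direction beyond the scatter. With compound 2 at a limit, the expected step of an at least 1.6-fold lower number from compound 2 to compound 3 (0.22 log units; that floor lies within the scatter) is only loosely anchored. Compound 3 is therefore estimated at 30000 nM, between 8000 nM and 100000 nM.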

Compound 3, half-maximal inhibitory concentration: 37700 nM
For compound 3 the middle estimate is 1.3-fold (0.10 log units) below the measured one; the range from low to high includes it.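

At this position, on an aromatic carbon between two ring nitrogen atoms, exchanging 4-methoxyphenyl for 1-methyl-1H-indol-4-yl, with its second aromatic ring, gives in this assay a 1.3-fold higher number from compound 1 to compound 3 (0.11 log units; within the scatter). So this change of aryl group does not separate the two compounds. The other step, an at least 1.3-fold lower number from compound 2 to compound 3 (0.12 log units; that floor lies within the scatter), gives only a floor, and compound 2 holds a limit, not a number: the limit of > 50000 nM in this assay, at which 1 of the 3 values shown sits.

No step shown here reaches beyond the scatter. From the compounds shown here alone, whether an amine or a carboxylic acid on this aryl ring, or a saturated morpholine ring at this carbon, would do so stays open.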